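This account rests on a few compounds, and the source may have more. Where it says the series, first, only, none or still open, it means among the compounds named here.

Working notes on the series. All values below come from a functional assay on HepG2 cells (Homo sapiens) for antiproliferative activity, read by XTT assay, with a stated time of 72 h; on this read-out lower numbers stand for stronger inhibition and higher numbers for weaker inhibition.

Compound 1 `C#Cc1cn([C@@H]2O[C@H](CO)[C@@H](O)[C@H]2O)c2ncnc(C)c12`: 290 nM
Compound 2 `COc1nc(N)nc2c1c(-c1cccs1)cn2[C@@H]1O[C@H](CO)[C@@H](O)[C@H]1O`: > 20000 nM, a limit of the assay rather than a number
Compound 3 `Cc1ncnc2c1c(-c1cccs1)cn2[C@@H]1O[C@H](CO)[C@@H](O)[C@H]1O`: > 15000 nM, likewise a limit of the assay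

Compound 3 and compound 1 share a core and differ in one place, (ethynyl in place of thiophen-2-yl on an aromatic carbon). In this assay this change gives an at least 51-fold lower number from compound 3 to compound 1 (1.71 log units; beyond the scatter). The size of that step is bounded only because the limit of > 15000 nM in this assay, at which 1 of the 3 values shown sits, is where compound 3 sits, so the true step may be larger. Compound 2 sits at a limit of its own, (the limit of > 20000 nM in this assay, at which 1 of the 3 values shown sits). The core of compound 2 and the core of compound 3 are not the same, and the difference between the two cores is not broken down here.

Compound 4 `C#Cc1cn([C@@H]2O[C@H](CO)[C@@H](O)[C@H]2O)c2nc(N)nc(OC)c12` has not been measured. It differs from compound 2 by ethynyl in place of thiophen-2-yl on an aromatic carbon, which is the same change, at the same kind of place, as the change from compound 3 to compound 1. The expectation for compound 4 in this assay is a step of an at least 13-fold lower number from compound 2 to compound 4 (1.12 log units; beyond the scatter), which rests on the step of an at least 51-fold lower number from compound 3 to compound 1 (1.71 log units; beyond the scatter) seen on the other core. Because compound 2 gives only a limit, > 20000 nM, the starting point is uncertain, and the estimate is kept broad. The estimated value for compound 4 is 1500 nM, with a range from 200 nM to 20000 nM.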

Compound 4, half-maximal inhibitory concentration: > 20000 nM
Compound 4 ended at the assay's limit; the forecaster's own chance of this, stated with the estimate: 25%; middle value at least 13-fold (1.12 log units) from the limit.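

No step can be read from compound 2 to compound 4, since both sit at the same limit of the assay, which is a limit and not a number: the limit of > 20000 nM in this assay, at which 2 of the 4 values shown sit. The compounds shown leave open how far the true values of compound 2 and compound 4 lie beyond that limit, and whether ethynyl in place of thiophen-2-yl changes the read-out at all on the core of compound 2.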